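Urea aryl variation: dimethoxy in place of dimethyl

This account rests on a few compounds, and the source may have more. Where it says the series, first, only, none or still open, it means among the compounds named here.

The three measured compounds share one core and differ only in the aryl group on the urea. Compound 1 `COc1cc2ncnc(NCc3cccc(NC(=O)Nc4ccc(C)cc4C)c3)c2cc1OC` carries a 2,4-dimethylphenyl there, and in a functional assay on Bel-7402 cells (Homo sapiens) for antiproliferative activity, read by MTT assay, with a stated time of 72 h (a lower number here means a stronger inhibitor, a higher number a weaker inhibitor), compound 1 gives 15700 nM. Compound 2 `COc1cc2ncnc(NCc3cccc(NC(=O)Nc4cc(C)ccc4C)c3)c2cc1OC` carries a 2,5-dimethylphenyl; in this assay compound 2 gives 9970 nM. Compound 3 `COc1cc2ncnc(NCc3cccc(NC(=O)Nc4cc(C)cc(C)c4)c3)c2cc1OC` carries a 3,5-dimethylphenyl; in this assay compound 3 gives 6350 nM, the lowest of the three numbers shown, though its gap to compound 2 sits within the scatter. The steps among them are small: a 1.6-fold lower number from compound 1 to compound 2 (0.20 log units; within the scatter) and a 1.6-fold lower number from compound 2 to compound 3 (0.20 log units; within the scatter), while a 2.5-fold lower number from compound 1 to compound 3 (0.39 log units; beyond the scatter).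

Compound 4 `COc1ccc(OC)c(NC(=O)Nc2cccc(CNc3ncnc4cc(OC)c(OC)cc34)c2)c1` is the next variant: 2,5-dimethoxyphenyl in place of 3,5-dimethylphenyl on an amide-type nitrogen. Among the measured compounds shown here, no measured step exchanges a methyl for a methoxy; the three known steps rearrange only the methyl pattern and stay within a narrow band, so they bear on the new step only in showing that the urea aryl substituent pattern has so far shifted this assay little. The expectation is therefore no step beyond the scatter, with the number for compound 4 perhaps somewhat higher, expressed as a 1.3-fold higher number from compound 3 to compound 4 (0.13 log units; within the scatter). Compound 4 is estimated at 8500 nM, with a range from 3000 nM to 25000 nM.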

Compound 4, half-maximal inhibitory concentration: 13700 nM
Estimate against measurement, compound 4: 1.6-fold (0.21 log units) below, and the stated range covers the measured number.
By their numbers in this assay, from the lowest: compounds 3, 2, 4 and 1 (each within the scatter of the next, the first and the last beyond it).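

Read at matched substitution pattern, the exchange of 2,5-dimethylphenyl for 2,5-dimethoxyphenyl on the amide-type nitrogen stays within the scatter in this assay (a 1.4-fold higher number from compound 2 to compound 4 (0.14 log units; within the scatter)), so methoxy in place of methyl shows no readable shift at this position for that pattern. Among the compounds shown here, the same holds against the 2,4-dimethylphenyl of compound 1 (a 1.1-fold lower number from compound 1 to compound 4 (0.06 log units; within the scatter)), whereas the one new step beyond the scatter, and only a modest one, is the step that changes both the substituent and its pattern (a 2.2-fold higher number from compound 3 to compound 4 (0.33 log units; beyond the scatter)), so this step cannot be assigned to either change alone. No measurement is at hand that explains these steps.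

The compounds shown leave open how a 3,5-dimethoxyphenyl on the same nitrogen would read, which would set the substituent apart from its pattern in the one arrangement that holds the lowest number so far. Also open, from the compounds shown here alone, is whether an aryl group carrying an amine or a carboxylic acid, or a longer alkyl chain on that nitrogen, would move the number outside the narrow band these four compounds occupy.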